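Cyano in place of propoxy on a dicarboxylic acid anilide

The compounds below may be only part of what the source reports. "The series", "measured", "known", "first", "only" and "open" are said of these compounds alone.

Measured so far:
Compound 1, `O=C(Nc1ccccc1)c1cccc(-c2nn[nH]n2)c1`: 38.1 mg/kg
Compound 2, `N#Cc1ccc(C(=O)Nc2cccc(-c3nn[nH]n3)c2)cc1`: 21.4 mg/kg
Compound 3, `CCCOc1ccc(C(=O)Nc2cc(C(=O)O)cc(C(=O)O)c2)cc1`: 78 mg/kg

All three were tested in a functional assay on the whole organism (stomach) with Rattus norvegicus as the target; a lower number here means that less compound is needed, a higher number that more compound is needed for the effect. Compound 3 stands at the highest of the three numbers: compound 1 gives the nearest lower number, and compound 2 lies furthest from compound 3, both gaps being beyond the usual scatter. Compound 3 carries a propoxy group and two carboxylic acids on its anilide, whereas compounds 1 and 2 share a tetrazole core of their own and differ from each other in the cyano group of compound 2.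

The next compound, compound 4, `N#Cc1ccc(C(=O)Nc2cc(C(=O)O)cc(C(=O)O)c2)cc1`, keeps the dicarboxylic acid core of compound 3 and changes one place: cyano in place of propoxy on an aromatic carbon. Among the compounds with values here, no step between two measured compounds matches this exchange, so the direction has to be read from the pair of compounds 1 and 2, where compound 2 with its cyano group shows the lower number. On that basis a moderate step downward in this assay is expected from compound 3 to compound 4, of roughly a 1.7-fold lower number from compound 3 to compound 4 (0.24 log units; within the scatter), though the different core leaves this uncertain. Compound 4 is therefore estimated at 45 mg/kg, with a plausible range from 18 mg/kg to 110 mg/kg.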

Compound 4, dose for 50% inhibition: 32.1 mg/kg
For compound 4 the middle estimate is 1.4-fold (0.15 log units) above the measured one; the measured number falls inside the stated range.
By their numbers in this assay, from the lowest: compounds 2, 4 and 1 (each within the scatter of the next); then compound 3.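

On the core with two carboxylic acids, the exchange on the aromatic carbon para to a large group can now be read directly in this assay, where cyano in place of propoxy gives a 2.4-fold lower number from compound 3 to compound 4 (0.39 log units; beyond the scatter). Within the data shown here, no earlier pair of compounds differed in one place only, so this is the first sign that this position affects the dose needed in the stomach of the rat, and that the propoxy group is not required for the effect, since compound 4 keeps a measurable dose with cyano in its place. Nothing shown here gives a measured reason for the size or direction of this step.

With only two groups seen at this position on this core, the compounds shown cannot separate the loss of the propoxy chain from the entry of the cyano group as the source of the lower number. On these data alone, how a shorter chain such as methoxy, a longer chain such as butoxy, or an amine would fall at this position stays open, as does whether the step would hold if either carboxylic acid were replaced.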